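Cytotoxicity of Acetylated and Free Nucleoside Analogues

The source may hold more compounds than are shown below. What is called first, only, known or untested is meant among the compounds shown, and "the series" means these compounds.

Compound 1 `CCCCCCCCc1cc(-c2cn([C@H]3C[C@H](O)[C@@H](CO)O3)c(=O)[nH]c2=O)on1` gives 3000 nM in an ADME assay on HeLa cells (Homo sapiens) for cytotoxicity; on this read-out higher numbers stand for lower toxicity in this test and lower numbers for higher toxicity in this test. Compound 3 `CC(C)(C)c1ccc(-c2cc(-c3cn([C@H]4C[C@H](O)[C@@H](CO)O4)c(=O)[nH]c3=O)on2)cc1` gives 3000 nM, and the step of no change at the digits printed from compound 1 to compound 3 (within the scatter) shows the swap leaves the read-out within scatter. Compound 2 `CCCc1cc(-c2cn([C@H]3C[C@H](OC(C)=O)[C@@H](COC(C)=O)O3)c(=O)[nH]c2=O)on1` gives 3000 nM and stands level with compound 1 and compound 3 at the digits shown.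

Compound 4 `CC(=O)OC[C@H]1O[C@@H](n2cc(-c3cc(-c4ccc(C(C)(C)C)cc4)no3)c(=O)[nH]c2=O)C[C@@H]1OC(C)=O` differs from compound 2 by 4-(tert-butyl)phenyl in place of propyl on an aromatic carbon. Within the data shown here, the only measured step of this kind, no change at the digits printed from compound 1 to compound 3 (within the scatter), is flat, so no change beyond the scatter is expected for the move from compound 2 to compound 4 in this assay, and the step is estimated as no change at the digits printed from compound 2 to compound 4 (within the scatter). Compound 4 is therefore expected to give 3000 nM, within a range of 1500 nM to 6000 nM.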

Compound 4, half-maximal cytotoxic concentration: 3000 nM
The estimate for compound 4 equals the measured number at the digits printed, and the stated range covers the measured number.
By their numbers in this assay, from the lowest: compounds 1, 2, 3 and 4 (each within the scatter of the next).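

In this assay, 4-(tert-butyl)phenyl on this aromatic carbon of the acetylated pair reads no change at the digits printed from compound 2 to compound 4 (within the scatter) and so stays within the scatter. With no change at the digits printed from compound 1 to compound 3 (within the scatter) in the free pair, the same entering group leaves the read-out flat whether propyl or octyl leaves. No measured evidence bears on why this position reads flat.

Going by these compounds, it remains open whether an amine or a carboxylic acid at this position would shift the read-out. A shorter chain such as methyl is equally untested here.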